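Amide to Urea: What to Expect for Compound 4

The source may hold more compounds than are shown below. What is called first, only, known or untested is meant among the compounds shown, and "the series" means these compounds.

Measured compounds:
compound 1 `COc1cc(-c2nn(-c3cccc(NC(=O)c4ccc(Cl)c(C(F)(F)F)c4)c3)cc2-c2ccncc2)ccc1Cl` – > 32500 nM
compound 2 `O=C(Nc1cccc(-n2cc(-c3ccncc3)c(-c3ccc(Cl)c(O)c3)n2)c1)Nc1cc(C(F)(F)F)cc(C(F)(F)F)c1` – 1400 nM
compound 3 `COc1cc(-c2nn(-c3cccc(NC(=O)Nc4cccc(C(F)(F)F)c4)c3)cc2-c2ccncc2)ccc1Cl` – 1650 nM

In a functional assay on LOX IMVI cells (Homo sapiens) for inhibition, read by sulforhodamine B assay, with a stated time of 48 h (on this read-out lower numbers stand for stronger inhibition of growth and higher numbers for weaker inhibition of growth), compound 1 gives only a limit, > 32500 nM, not a number; on the numbers shown it sits at the weak end. Compound 4 `COc1cc(-c2nn(-c3cccc(NC(=O)Nc4ccc(Cl)c(C(F)(F)F)c4)c3)cc2-c2ccncc2)ccc1Cl` differs from compound 1 in one place: (4-chloro-3-(trifluoromethyl)phenyl)amino in place of 4-chloro-3-(trifluoromethyl)phenyl on a carbonyl carbon. Going by the values given here, one measured step bears on this change, an at least 19-fold lower number from compound 1 to compound 3 (1.29 log units; beyond the scatter), where the same amide-to-urea conversion carried a different aryl group. Compound 2, also a urea, gives 1400 nM in this assay. A step of similar size and direction is therefore expected for compound 4, namely an at least 21-fold lower number from compound 1 to compound 4 (1.33 log units; beyond the scatter). Compound 4 is expected to give about 1500 nM in this assay, with a range from 600 nM to 4000 nM.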

Compound 4, concentration for total growth inhibition: 4610 nM
The estimate for compound 4 lay 3.1-fold (0.49 log units) below the measured number, outside the stated range (above it).
By their numbers in this assay, from the lowest: compounds 2 and 3 (each within the scatter of the next); then compound 4. At a limit, above all of these: compound 1.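

Changing the amide to a urea also lowers the number when the 4-chloro-3-(trifluoromethyl)phenyl group is kept, with an at least 7.0-fold lower number from compound 1 to compound 4 (0.84 log units; beyond the scatter). This step gives only a minimum size, because compound 1 is held at a limit and not a number: the limit of > 32500 nM in this assay, at which 1 of the 4 values shown sits. Among the ureas, the aromatic chloro is not neutral, as adding it gives a 2.8-fold higher number from compound 3 to compound 4 (0.45 log units; beyond the scatter), so the urea's gain depends partly on the aryl group it carries.

The compounds shown do not explain why the chloro raises the number. They also leave open how a fluoro or methyl group would read at that aromatic carbon.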